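The source may hold more compounds than are shown below. What is called first, only, known or untested is meant among the compounds shown, and "the series" means these compounds.

Compound 3 `COc1cccc(CNCCCNc2ccnc3cc(-c4cccc5ccccc45)ccc23)c1O` gives 9.47 in a physicochemical assay for acid dissociation, level with compound 1 `COc1cccc(CNCCCNc2ccnc3cc(CCC(C)C)ccc23)c1O` at 9.47, both standing together at the top of three numbers; compound 2 `COc1cccc(CNCCCNc2ccnc3cc(Oc4ccccc4)ccc23)c1O` gives 9.28, and the step of a number 0.19 log units higher from compound 2 to compound 3 (within the scatter) stays within the scatter. Compound 4 `COc1cccc(CNCCCNc2ccnc3cc(CC(C)C)ccc23)c1O` differs from compound 3 in one place: isobutyl in place of naphthalen-1-yl on an aromatic carbon. The step that bears most on this is no change at the digits printed from compound 1 to compound 3 (within the scatter), since isopentyl and isobutyl are both short chains without a ring and that exchange against naphthalen-1-yl left the number untouched. He therefore expects no step beyond the scatter, no change at the digits printed from compound 3 to compound 4 (within the scatter). His estimate for compound 4 in this assay is 9.47, with a range from 9.2 to 9.75.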

Compound 4, acid dissociation constant: 9.47
Compound 4: middle estimate and measured number agree at the digits printed; the measured number falls inside the stated range.
By their numbers in this assay, from the lowest: compounds 2, 1, 3 and 4 (each within the scatter of the next).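

In this assay, isobutyl in place of naphthalen-1-yl gives (no change at the digits printed from compound 3 to compound 4 (within the scatter)), so a group with no ring now stands level with one carrying two aromatic rings at this aromatic carbon. The two chains compare the same way (no change at the digits printed from compound 1 to compound 4 (within the scatter)), and the exchange of phenoxy for isobutyl also stays small (a number 0.19 log units higher from compound 2 to compound 4 (within the scatter)). Nothing available explains this flatness. As far as these compounds go, whether an amine, a carboxylic acid or a longer chain here would move the number beyond the scatter remains open.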